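What a new ring may do to compound 3

The compounds below may be only part of what the source reports. "The series", "measured", "known", "first", "only" and "open" are said of these compounds alone.

Of the compounds shown here, three with a shared core have been measured: compound 1 `CC(C)(O/N=C(\C(=O)N[C@@H]1C(=O)N(S(=O)(=O)O)[C@@H]1CN1CCC1=O)c1csc(N)n1)C(=O)O`, compound 2 `CC(C)(O/N=C(\C(=O)N[C@@H]1C(=O)N(S(=O)(=O)O)[C@@H]1CN1CCCCC1=O)c1csc(N)n1)C(=O)O` and compound 3 `CC(C)(O/N=C(\C(=O)N[C@@H]1C(=O)N(S(=O)(=O)O)[C@@H]1Cn1ccnn1)c1csc(N)n1)C(=O)O`. In a physicochemical assay for metabolic stability, read by HPLC and mass spectrometry, in phosphate buffer, at 37 degrees C, at pH 7.4 (a higher number here means that the compound lasts longer, a lower number that the compound disappears faster), compound 1 gives > 1000 h, which is a limit of the assay and not a number. In this assay, compound 2 gives 214 h and compound 3 gives 257 h, so compound 3 stands level with compound 2.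

Compound 4 `C[C@@H]1CN(C[C@@H]2[C@H](NC(=O)/C(=N\OC(C)(C)C(=O)O)c3csc(N)n3)C(=O)N2S(=O)(=O)O)C(=O)O1` changes one place, on a saturated chain carbon bound to a saturated ring carbon, where 5-methyl-2-oxo-1,3-oxazolidin-3-yl replaces 1H-1,2,3-triazol-1-yl: 5-methyl-2-oxo-1,3-oxazolidin-3-yl in place of 1H-1,2,3-triazol-1-yl on a saturated chain carbon bound to a saturated ring carbon.

Earlier swaps at this place bear on the question. Two that leave the 2-oxoazetidin-1-yl group gave an at least 4.6-fold lower number from compound 1 to compound 2 (0.66 log units; beyond the scatter) and an at least 3.8-fold lower number from compound 1 to compound 3 (0.59 log units; beyond the scatter), both beyond the scatter. Among the measured compounds shown here, the only step between two true numbers, a 1.2-fold higher number from compound 2 to compound 3 (0.08 log units; within the scatter), lies within the scatter. Compound 4 keeps neither of these groups, and no step beyond the scatter is expected in this assay. The expected step is a 1.2-fold higher number from compound 3 to compound 4 (0.07 log units; within the scatter). For compound 4 the estimate is 300 h, with an expected range from 120 h to 800 h.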

Compound 4, half-life: > 37 h
Compound 4 was reported as a limit; the forecaster's own chance of this, stated with the estimate: 10%; the middle value does not contradict the limit.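

In this assay compound 4 gives > 37 h, which is a limit of the assay and not a number. Its steps from compound 1, compound 2 and compound 3 therefore cannot be read. The compounds shown leave open whether 5-methyl-2-oxo-1,3-oxazolidin-3-yl in place of 1H-1,2,3-triazol-1-yl changes the half-life at all.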